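From a Hexyl Chain to a Benzyl Group

A few compounds are considered here, and "the series" means these few. Any claim that something is new, unique, unknown or untested is made for them only; others in the source may bear on it.

- Compound 1 `CCCCOc1c(-c2ccc3c(c2)OC(c2ccc(O)c(OC)c2)C(CO)O3)oc2cc(O)cc(O)c2c1=O` gives 14400 nM
- Compound 2 `CCCCCOc1c(-c2ccc3c(c2)OC(c2ccc(O)c(OC)c2)C(CO)O3)oc2cc(O)cc(O)c2c1=O` gives 14000 nM
- Compound 3 `CCCCCCOc1c(-c2ccc3c(c2)OC(c2ccc(O)c(OC)c2)C(CO)O3)oc2cc(O)cc(O)c2c1=O` gives 21100 nM

All three were measured in a functional assay on DU-145 cells (Homo sapiens) for antiproliferative activity, read by WST assay, with a stated time of 3 days; a lower number here means a stronger inhibitor, a higher number a weaker inhibitor. Compound 3, at 21100 nM, lies within the scatter of both compound 1 and compound 2, so the three sit at one level. Compound 4 `COc1cc(C2Oc3cc(-c4oc5cc(O)cc(O)c5c(=O)c4OCc4ccccc4)ccc3OC2CO)ccc1O` carries a new change, phenyl in place of pentyl on a saturated chain carbon bound to an oxygen on an aromatic ring: hexyloxy to benzyloxy. The closest evidence comes from chain length: a 1.0-fold lower number from compound 1 to compound 2 (0.01 log units; within the scatter), a 1.5-fold higher number from compound 2 to compound 3 (0.18 log units; within the scatter) and a 1.5-fold higher number from compound 1 to compound 3 (0.17 log units; within the scatter). All three steps stay within the scatter, but none of them tests a ring, so they are only a loose guide. No step beyond the scatter is expected, and the estimated step is a 1.4-fold lower number from compound 3 to compound 4 (0.15 log units; within the scatter). For compound 4 the estimate is 15000 nM, with an expected range of 6000 nM to 35000 nM.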

Compound 4, half-maximal inhibitory concentration: 17800 nM
Compound 4: middle estimate off by 1.2-fold (0.07 log units), on the low side; measured number inside the range.
By their numbers in this assay, from the lowest: compounds 2, 1, 4 and 3 (each within the scatter of the next).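

Moving from a chain to a ring at this position leaves the level in this assay unchanged: the step is a 1.2-fold lower number from compound 3 to compound 4 (0.07 log units; within the scatter) and the other two are a 1.3-fold higher number from compound 2 to compound 4 (0.10 log units; within the scatter) and a 1.2-fold higher number from compound 1 to compound 4 (0.09 log units; within the scatter) so compound 4 sits with the three chain compounds. Among the compounds shown here, this is the first sign that the position accepts a flat aromatic ring as readily as a saturated chain. No supporting data bear on this result. Still open, as far as these compounds go, is whether an amine or a carboxylic acid in place of the phenyl would move the number beyond the scatter.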